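A Pyridin-2-yl Variant of Compound 1

This account rests on a few compounds, and the source may have more. Where it says the series, first, only, none or still open, it means among the compounds named here.

Within the data shown here, compound 1 `Cc1ccc(/C=C2/S/C(=N/c3ccccc3)N(Cc3ccncc3)C2=O)cc1` gives 36900 nM in a functional assay on MCF7 cells (Homo sapiens) for cytotoxicity, read by MTT assay, with a stated time of 48 h (a higher number here means a weaker inhibitor, a lower number a stronger inhibitor), the highest of the two numbers measured so far. Compound 2 `COc1ccc(/C=C2/S/C(=N/c3ccccc3)N(Cc3ccncc3)C2=O)cc1` gives 31500 nM in this assay, and the step of a 1.2-fold lower number from compound 1 to compound 2 (0.07 log units; within the scatter) lies within the scatter. Compound 3 `O=C1/C(=C\c2ccccn2)S/C(=N/c2ccccc2)N1Cc1ccncc1` differs from compound 1 in one place: pyridin-2-yl in place of 4-methylphenyl on a double-bonded chain carbon bound to a double-bonded ring carbon. Among the measured compounds shown here, no measured step exchanges one aromatic ring for another, so the single known step, methoxy for methyl, bears only loosely on this change. Compound 3 is therefore expected to differ little, an estimated step of a 1.1-fold lower number from compound 1 to compound 3 (0.02 log units; within the scatter). The expected value for compound 3 is 35000 nM, ranging from 15000 nM to 80000 nM.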

Compound 3, half-maximal inhibitory concentration: 21100 nM
Compound 3: middle estimate off by 1.7-fold (0.22 log units), on the high side, and the stated range covers the measured number.
By their numbers in this assay, from the lowest: compounds 3, 2 and 1 (each within the scatter of the next).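

The step of a 1.7-fold lower number from compound 1 to compound 3 (0.24 log units; within the scatter) and the step of a 1.5-fold lower number from compound 2 to compound 3 (0.17 log units; within the scatter) show that in this assay this place tolerates more than a swap of substituent on the aromatic ring. Pyridin-2-yl, with a ring nitrogen and a hydrogen-bond acceptor that 4-methylphenyl lacks, replaces the whole ring without a change beyond the scatter. Whether an amine or a carboxylic acid at this place would move the number beyond the scatter remains open, as every step shown stays within it. Nothing available explains these small steps.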